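Fluoro added to the bromophenyl ring of compound 3

The source may report more compounds than this note shows. Statements on the series, on what has been measured and on what is new or still open speak of the compounds shown alone.

Measured so far:
compound 1 `Cn1ccc2c(Oc3ccc(NC(=O)c4cn(-c5ccc(Br)cc5)c5ccccc5c4=O)cc3F)ccnc21` gives 1390 nM
compound 2 `Cn1ccc2c(Oc3ccc(NC(=O)c4cn(-c5ccc(Br)cc5F)c5ccccc5c4=O)cc3F)ccnc21` gives 1520 nM
compound 3 `O=C(Nc1ccc(Oc2ccnc3[nH]ccc23)c(F)c1)c1cn(-c2ccc(Br)cc2)c2ccccc2c1=O` gives 950 nM

All three numbers come from a functional assay on A549 cells (Homo sapiens) for inhibition, read by MTT assay, with a stated time of 72 h; a higher number here means a weaker inhibitor, a lower number a stronger inhibitor. Compound 2 differs from compound 1 by fluoro in place of hydrogen on an aromatic carbon, and this step reads a 1.1-fold higher number from compound 1 to compound 2 (0.04 log units; within the scatter). Compound 3 differs from compound 1 by hydrogen in place of methyl on an aromatic nitrogen, and this step reads a 1.5-fold lower number from compound 1 to compound 3 (0.17 log units; within the scatter). Compound 2 and compound 3 share no counted difference, so their two values stand side by side without a step.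

Compound 4 `O=C(Nc1ccc(Oc2ccnc3[nH]ccc23)c(F)c1)c1cn(-c2ccc(Br)cc2F)c2ccccc2c1=O` has not been measured in this assay. It differs from compound 3 by fluoro in place of hydrogen on an aromatic carbon. This is the same change that was made from compound 1 to compound 2, and the place of the change is described in the same words in both pairs. The two cores differ by hydrogen in place of methyl on an aromatic nitrogen.

The expectation is that the step from compound 3 to compound 4 is estimated as a 1.1-fold higher number from compound 3 to compound 4 (0.04 log units; within the scatter), resting on the earlier step of a 1.1-fold higher number from compound 1 to compound 2 (0.04 log units; within the scatter). Compound 4 is therefore expected to give about 1050 nM, estimated to fall between 500 nM and 2200 nM.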

Compound 4, half-maximal inhibitory concentration: 1150 nM
The estimate for compound 4 lay 1.1-fold (0.04 log units) below the measured number, and the stated range covers the measured number.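

Fluoro in place of hydrogen gave a 1.2-fold higher number from compound 3 to compound 4 (0.08 log units; within the scatter) in this assay, and this step carried from one core to the other: the same change on two cores in this assay, a 1.1-fold higher number (0.04 log units; within the scatter) from compound 1 to compound 2 and a 1.2-fold higher number (0.08 log units; within the scatter) from compound 3 to compound 4, 1.1-fold (0.04 log units) apart, within the scatter of two such steps. Hydrogen in place of methyl on the aromatic nitrogen gave a 1.3-fold lower number from compound 2 to compound 4 (0.12 log units; within the scatter), and this change also carried across the two compounds that bear it: the same change on two cores in this assay, a 1.5-fold lower number (0.17 log units; within the scatter) from compound 1 to compound 3 and a 1.3-fold lower number (0.12 log units; within the scatter) from compound 2 to compound 4, 1.1-fold (0.04 log units) apart, within the scatter of two such steps. All of these steps lie within the scatter, so the agreement is one between steps too small to tell from repeat measurements, and it does not show that a change with a larger effect would carry between these cores in the same way.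

The compounds shown leave open how other groups would read at the same place on the 4-bromophenyl ring, such as chloro, methoxy or an amine. They also leave open whether an ethyl group or a longer chain on the aromatic nitrogen would read as methyl and hydrogen do in this assay.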